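Replacing a Methylphenyl Ether with a Cyanophenyl Ether

A few compounds are considered here, and "the series" means these few. Any claim that something is new, unique, unknown or untested is made for them only; others in the source may bear on it.

Of the compounds shown here, three sharing one core have been tested in a functional assay on Flp-In T-REx293 cells for antagonist activity at Free fatty acid receptor 1 (Homo sapiens), read by calcium flux; on this read-out higher numbers stand for weaker inhibition and lower numbers for stronger inhibition. Compound 1 `O=S1(=O)c2ccccc2CN1c1cc(F)cc(Oc2cccnc2)c1` carries a pyridin-3-yl on an oxygen on an aromatic ring. In this assay compound 1 reaches only the limit > 100000 nM, which is not a number. Compound 2 `O=S1(=O)c2ccccc2CN1c1cc(F)cc(OCc2ccccc2)c1` has a benzyl there and in this assay compound 2 gives 2450 nM. Compound 3 `Cc1cccc(Oc2cc(F)cc(N3Cc4ccccc4S3(=O)=O)c2)c1`, with a 3-methylphenyl, gives 25100 nM in this assay and stands highest among the two numbers, the step being a 10-fold higher number from compound 2 to compound 3 (1.01 log units; beyond the scatter). Compound 4 `N#Cc1ccccc1Oc1cc(F)cc(N2Cc3ccccc3S2(=O)=O)c1` differs from compound 3 by 2-cyanophenyl in place of 3-methylphenyl on an oxygen on an aromatic ring. Among the measured compounds shown here, no measured step bears directly on a nitrile; the only nearby step with a hydrogen-bond acceptor is an at least 3.9-fold lower number from compound 1 to compound 3 (0.60 log units; beyond the scatter). For compound 4 the expected value in this assay is 30000 nM, within 8000 nM to 150000 nM, an expected step of a 1.2-fold higher number from compound 3 to compound 4 (0.08 log units; within the scatter).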

Compound 4, half-maximal inhibitory concentration: > 100000 nM
Compound 4: only a limit was reported; the forecaster's own chance of this, stated with the estimate: 30%; middle value at least 3.3-fold (0.52 log units) away from the limit.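

In this assay, 2-cyanophenyl in place of 3-methylphenyl gives an at least 3.9-fold higher number from compound 3 to compound 4 (0.60 log units; beyond the scatter) and, set against the benzyl, gives an at least 40-fold higher number from compound 2 to compound 4 (1.61 log units; beyond the scatter) on this oxygen, so an aromatic ring of carbon only does not by itself keep the inhibition seen with compound 3. Compound 4 gives only a limit, and it is the second compound to do so: the limit of > 100000 nM in this assay, at which 2 of the 4 values shown sit. The two limits leave the step between compound 1 and compound 4 unreadable.

Going by these compounds, whether the loss follows the nitrile itself or its position on the ring stays open, as does the effect of an amine or a carboxylic acid on that ring.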